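Moving the Bromine Around the Phenyl Ring

A few compounds are considered here, and "the series" means these few. Any claim that something is new, unique, unknown or untested is made for them only; others in the source may bear on it.

In an ADME assay on HepG2 cells (Homo sapiens) for cytotoxicity, read by sulforhodamine B assay, with a stated time of 48 h (a higher number here means that more compound is tolerated, a lower number that less compound is tolerated), compound 2 `COc1nc2ccccc2cc1/C=C/c1noc(-c2ccc(Br)cc2)n1` gives > 195000 nM, which is a limit of the assay rather than a number. Compound 1 `COc1nc2ccccc2cc1/C=C/c1noc(-c2ccccc2)n1` likewise gives > 240000 nM, again a limit. Compound 3 `COc1nc2ccccc2cc1/C=C/c1noc(-c2ccc(F)cc2)n1` gives > 230000 nM, also a limit. The steps a step that the two limits leave unreadable from compound 1 to compound 2, a step that the two limits leave unreadable from compound 1 to compound 3 and a step that the two limits leave unreadable from compound 2 to compound 3 therefore cannot be read. Compound 4 `COc1nc2ccccc2cc1/C=C/c1noc(-c2ccccc2Br)n1` differs from compound 2 by 2-bromophenyl in place of 4-bromophenyl on an aromatic carbon. With every measured step unreadable and every measured value a limit, no step beyond the scatter is expected in this assay, and compound 4 is expected to sit at a limit as well. The step that the limit leaves unreadable from compound 2 to compound 4 is expected to be small. Compound 4 is estimated at 200000 nM, with a range from 100000 nM to 300000 nM.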

Compound 4, half-maximal cytotoxic concentration: > 195000 nM
Compound 4: no number, only a limit; the forecaster's own chance of this, stated with the estimate: 85%; the middle value is on the limit's open side.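

Going by these compounds alone, compound 4 gives only a limit in this assay, and no step from it to compound 1, compound 2 or compound 3 can be read. The compounds shown leave open what concentration any of them tolerates before harming the cells, and whether moving the bromine changes it.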